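Chloro to iodo exchange in the series: compound 4 forecast

The compounds below may be only part of what the source reports. "The series", "measured", "known", "first", "only" and "open" are said of these compounds alone.

Measured compounds:
- In a functional assay on IGROV-1 cells (Homo sapiens) for inhibition (on this read-out higher numbers stand for weaker inhibition of growth and lower numbers for stronger inhibition of growth), compound 1 `Nc1ccc(-c2nc3ccc(F)cc3s2)cc1I` gives < 10 nM.
- In this assay compound 2 `Nc1ccc(-c2nc3ccc(F)cc3s2)cc1Cl` gives < 10 nM.
- In this assay compound 3 `Nc1ccc(-c2nc3cc(F)ccc3s2)cc1Cl` gives < 10 nM.

Each of these three values is a limit of the assay and not a number; all three sit at the limit of < 10 nM in this assay, at which 3 of the 3 values shown sit.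

From compound 2 to compound 1 the change is iodo in place of chloro on an aromatic carbon, and the resulting step is a step that the two limits leave unreadable from compound 2 to compound 1. Compound 2 and compound 3 have the same atoms joined differently; the difference between the two cores is not broken down here.

Compound 4 `Nc1ccc(-c2nc3cc(F)ccc3s2)cc1I` is not yet measured in this assay. From compound 3 to compound 4 the change is iodo in place of chloro on an aromatic carbon, the same change as from compound 2 to compound 1, with the surroundings of the place described in the same words.

Compound 3 gives only < 10 nM, a limit of the assay. Compound 4 is expected to move by a step that the limit leaves unreadable from compound 3 to compound 4, an expectation that rests on the unreadable size of a step that the two limits leave unreadable from compound 2 to compound 1 and on the limit at which compound 3 sits. Compound 4 is therefore estimated at 5 nM, with a likely range from 1 nM to 15 nM, and most probably the assay will again report only a limit.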

Compound 4, concentration for 50% growth inhibition: < 10 nM
Compound 4: no number, only a limit (the forecaster's own chance of this, stated with the estimate: 80%); the middle value lies beyond the limit too.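

In this assay compound 4 gives < 10 nM, a limit of the assay and not a number. Compound 3 also sits at a limit, so no step can be read from compound 3 to compound 4: the limit of < 10 nM in this assay, at which 4 of the 4 values shown sit.

The compounds shown leave open how compound 1, compound 2, compound 3 and compound 4 stand against one another, and whether iodo in place of chloro changes growth inhibition at all.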